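Trimming a Methyl Group from Compound 1

The compounds below may be only part of what the source reports. "The series", "measured", "known", "first", "only" and "open" are said of these compounds alone.

Three closely related compounds have been measured in a functional assay on A549 cells (Homo sapiens) for inhibition, read by MTT assay, with a stated time of 72 h; on this read-out lower numbers stand for stronger inhibition and higher numbers for weaker inhibition. Compound 1 `COc1cc2c(Oc3ccc(NC(=O)c4nn(-c5ccccc5C)cc(C)c4=O)c(F)c3)ccnc2cc1OCCCCCCC(=O)NO` gives 4280 nM. Compound 2 `COc1cc2c(Oc3ccc(NC(=O)c4nn(-c5ccccc5C)cc(C)c4=O)cc3F)ccnc2cc1OCCCC(=O)NO` gives 2090 nM, and compound 3 `COc1cc2c(Oc3ccc(NC(=O)c4nn(-c5ccccc5)cc(C)c4=O)cc3F)ccnc2cc1OCCCC(=O)NO` gives 1900 nM. Compound 1 has the highest number of the three; the difference between its core and that of compound 2 is not broken down here. Compounds 2 and 3 differ in one place, hydrogen in place of methyl on an aromatic carbon and this change gave a 1.1-fold lower number from compound 2 to compound 3 (0.04 log units; within the scatter).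

Compound 4 `COc1cc2c(Oc3ccc(NC(=O)c4nn(-c5ccccc5C)ccc4=O)c(F)c3)ccnc2cc1OCCCCCCC(=O)NO` has not yet been measured. It differs from compound 1 by hydrogen in place of methyl on an aromatic carbon This is the same kind of change as from compound 2 to compound 3, but not the same: there the methyl left a six-membered aromatic ring of carbon only, ortho to a large group, whereas here it leaves a six-membered aromatic ring with 2 nitrogen, ortho to a group of 1 heavy atom, two atoms from the ring nitrogen, meta to a 2-methylphenyl group, meta to a large group, opposite the ring nitrogen. Because a 1.1-fold lower number from compound 2 to compound 3 (0.04 log units; within the scatter) stayed within the scatter, only a small step is expected for compound 4, a 1.1-fold lower number from compound 1 to compound 4 (0.03 log units; within the scatter), with a wider range to allow for the different place. Compound 4 is therefore estimated at 4000 nM, between 2000 nM and 8000 nM.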

Compound 4, half-maximal inhibitory concentration: > 20000 nM
Compound 4: a limit, no number; the forecaster's own chance of this, stated with the estimate: 5%; middle value at least 5.0-fold (0.69 log units) away from the limit.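

In this assay compound 4 gives > 20000 nM, which is a limit of the assay and not a number. Even so, the step can be read as an at least 4.6-fold higher number from compound 1 to compound 4 (0.66 log units; beyond the scatter), so replacing methyl with hydrogen cannot be assumed to have a similar effect wherever it is made in this series: the same change on two cores in this assay, a 1.1-fold lower number (0.04 log units; within the scatter) from compound 2 to compound 3 and an at least 4.6-fold higher number (0.66 log units; beyond the scatter) from compound 1 to compound 4, at least 5.1-fold (0.71 log units) apart, beyond the scatter of two such steps The result does not give the true size of the step, nor does it show what accounts for the gap, since the two steps sit at different places on different cores and the limit leaves the value of compound 4 open: the limit of > 20000 nM in this assay, at which 1 of the 4 values shown sits.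

Still open, going by these compounds, is whether removing the methyl from the six-membered aromatic ring with 2 nitrogen would give a similar step on the core of compound 2, which would help separate the place of the change from the rest of the core. Also open, on these data alone, is how an ethyl group or a chlorine atom on that same aromatic carbon would compare with the methyl of compound 1.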